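Oxolane-bearing analogue of the dimethylisoxazole compound 3

The source may report more compounds than this note shows. Statements on the series, on what has been measured and on what is new or still open speak of the compounds shown alone.

In a functional assay on KARPAS-422 cells (Homo sapiens) for antiproliferative activity, read by resazurin assay, with a stated time of 72 h (on this read-out higher numbers stand for weaker inhibition and lower numbers for stronger inhibition), the most potent member so far is compound 3 `Cc1cc(C)c(CN2CCc3c(Cl)cc(-c4c(C)noc4C)c(Cl)c3C2=O)c(=O)[nH]1`, which gives 23 nM. The other two members are compound 1 `Cc1cc(C)c(CN2CCc3c(Cl)cc([C@@H](CO)[C@@H]4CCOC4)c(Cl)c3C2=O)c(=O)[nH]1` with 3950 nM and compound 2 `Cc1cc(C)c(CN2CCc3c(Cl)cc([C@@H](C)CO)c(Cl)c3C2=O)c(=O)[nH]1` with 1500 nM; compound 3 stands clearly apart from both, with a 65-fold lower number from compound 2 to compound 3 (1.81 log units; beyond the scatter) and a 170-fold lower number from compound 1 to compound 3 (2.23 log units; beyond the scatter). The remaining step within the measured set, a 2.6-fold lower number from compound 1 to compound 2 (0.42 log units; beyond the scatter), is modest.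

Compound 4 `Cc1cc(C)c(CN2CCc3c(Cl)cc([C@H](CO)[C@@H]4CCCO4)c(Cl)c3C2=O)c(=O)[nH]1` is now to be measured in this assay. Relative to compound 3 the change is a group of 8 heavy atoms (6 carbon, 2 oxygen; one five-membered non-aromatic ring with 1 hetero atom) in place of a group of 7 heavy atoms (5 carbon, 1 nitrogen, 1 oxygen; one five-membered aromatic ring with 2 hetero atoms), on an aromatic carbon. The entering group matches the group of compound 1 in its counts, though compound 4 and compound 1 are distinct compounds. Within the data shown here, the steps that bear on this change are the two that run into compound 3, a 170-fold lower number from compound 1 to compound 3 (2.23 log units; beyond the scatter) and a 65-fold lower number from compound 2 to compound 3 (1.81 log units; beyond the scatter); both were large, and the present change reverses the first of them in kind. A large step upward is therefore expected for compound 4, taking it back toward the range of compound 1 and compound 2, with the exact landing uncertain.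

The expected step is a 130-fold higher number from compound 3 to compound 4 (2.12 log units; beyond the scatter). Compound 4 is estimated at 3000 nM, within a range from 900 nM to 10000 nM.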

Compound 4, half-maximal inhibitory concentration: 57 nM
Compound 4: the middle estimate sits 53-fold (1.72 log units) above what was measured; the whole stated range lies above it.
By their numbers in this assay, from the lowest: compound 3; then compound 4; then compound 2; then compound 1.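

Notes on the position on the aromatic carbon, ortho to a chloro group, in this assay: a non-aromatic group can stand here at little cost relative to 3,5-dimethyl-1,2-oxazol-4-yl, as the oxolane-bearing group of compound 4 shows (a 2.5-fold higher number from compound 3 to compound 4 (0.39 log units; beyond the scatter)), a modest step though beyond the scatter. The weak numbers of the two earlier non-aromatic groups therefore do not extend to every such group, and on the same chain oxolan-2-yl in place of methyl brings a large gain (a 26-fold lower number from compound 2 to compound 4 (1.42 log units; beyond the scatter)). Atom counts alone do not decide the outcome at this position: the groups of compound 1 and compound 4 match in their counts yet remain far apart (a 69-fold lower number from compound 1 to compound 4 (1.84 log units; beyond the scatter)), so the arrangement of the oxolane-bearing group matters here.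

Still open, from the compounds shown here alone, is how far the ring attachment and the stereocentres each contribute, as these vary together between compound 1 and compound 4, and whether an amine or a carboxylic acid in place of the hydroxymethyl would hold the number of compound 4. Nothing measured here explains any of these steps.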